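The compounds below may be only part of what the source reports. "The series", "measured", "known", "first", "only" and "open" are said of these compounds alone.

Working notes on the sulfonyl series. Compound 1 `CC1CCN(c2c(S(=O)(=O)c3cccc(F)c3)cnc3ccc(F)cc23)CC1`, compound 2 `Cc1ccc(S(=O)(=O)c2cnc3ccc(F)cc3c2N2CCC(C)CC2)cc1Cl` and compound 3 `COc1ccc(S(=O)(=O)c2cnc3ccc(F)cc3c2N2CCC(C)CC2)cc1Cl` share one core and differ only in the aryl group on the sulfonyl sulfur. In an assay on isolated protein for displacement of a labelled ligand from metabotropic glutamate receptor 5 (Homo sapiens), with a stated time of 60 min, tested at 1 uM (a higher number here means more inhibition at the concentration tested (going by the name of the read-out), a lower number less inhibition), compound 1 gives 76%, compound 2 gives 91% and compound 3 gives 82%. Among the compounds with values here, compound 3 thus stands second highest of the three, with a number 6 percentage points higher from compound 1 to compound 3 (within the scatter) and a number 9 percentage points lower from compound 2 to compound 3 (within the scatter); the only step beyond scatter is a number 15 percentage points higher from compound 1 to compound 2 (beyond the scatter). Compound 4 `CC1CCN(c2c(S(=O)(=O)c3cc(Cl)cc(Cl)c3)cnc3ccc(F)cc23)CC1` carries 3,5-dichlorophenyl in place of 3-chloro-4-methoxyphenyl on a sulfonyl sulfur. All three measured steps exchange aryl groups on this sulfur and keep the read-out in a narrow band, so no shift beyond the scatter is expected for compound 4 in this assay. Compound 4 is estimated at 85% (range 70% to 96%), which means an expected step of a number 3 percentage points higher from compound 3 to compound 4 (within the scatter).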

Compound 4, a percentage reported as inhibition, at one concentration (the size of the read-out at that concentration, not a potency): 69%
The estimate for compound 4 lay 16 percentage points above the measured number, outside the stated range (below it).
By their numbers in this assay, from the lowest: compounds 4, 1, 3 and 2 (each within the scatter of the next, the first and the last beyond it).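

On the sulfonyl sulfur, 3,5-dichlorophenyl shows that an aryl exchange can move the read-out in this assay beyond the scatter in more than one pair, with a number 13 percentage points lower from compound 3 to compound 4 (beyond the scatter) and a number 22 percentage points lower from compound 2 to compound 4 (beyond the scatter), while a number 7 percentage points lower from compound 1 to compound 4 (within the scatter) stays within it. The number in this assay is therefore not level across every aryl group at this position, and compound 4 sits beyond the scatter from both 3-chloro-4-substituted compounds. Nothing available accounts for these steps.

Still open, going by these compounds, is how an unsubstituted phenyl on this sulfur would read, and whether an amine or a carboxylic acid on the aryl ring would keep the read-out.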